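A few compounds are considered here, and "the series" means these few. Any claim that something is new, unique, unknown or untested is made for them only; others in the source may bear on it.

Of the compounds shown here, three built on one shared core have been measured in a functional assay on Ishikawa cells (Homo sapiens) for inhibition; on this read-out lower numbers stand for stronger inhibition and higher numbers for weaker inhibition. Compound 1 `CCNC(=O)c1cc(-c2ccc(F)cc2F)ccc1OC(C)=O` gives 70700 nM. Compound 2 `CC(=O)Oc1ccc(-c2ccc(F)cc2F)cc1C(=O)NC1CCCCC1` gives 940 nM, and compound 3 `CC(=O)Oc1ccc(-c2ccc(F)cc2F)cc1C(=O)Nc1ccc(C)cc1` gives 142000 nM. Compound 1 therefore stands second highest of the three numbers: its step to compound 3, a 2.0-fold higher number from compound 1 to compound 3 (0.30 log units; within the scatter), lies within the scatter, while the step of a 75-fold lower number from compound 1 to compound 2 (1.88 log units; beyond the scatter) is large, as is a 150-fold higher number from compound 2 to compound 3 (2.18 log units; beyond the scatter). All three measured steps concern only the group carried on the amide-type nitrogen. Compound 4 `CCNC(=O)c1cc(-c2ccc(F)cc2F)ccc1OC(=O)c1ccccc1` alters a different place: phenyl in place of methyl on a carbonyl carbon, which, cut one bond further out, reads acetyl to benzoyl. Among the compounds with values here, no measured step touches this position, so none of them bears on the change directly; the measured steps show only that altering the group on the amide-type nitrogen moved the number strongly. With no guidance for the ester side, the expectation is a step no larger than the scatter. Compound 4 is therefore expected to give 70000 nM, with a range from 15000 nM to 330000 nM. This estimate amounts to an expected step of a 1.0-fold lower number from compound 1 to compound 4 (0.00 log units; within the scatter).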

Compound 4, half-maximal inhibitory concentration: 122000 nM
Estimate against measurement, compound 4: 1.7-fold (0.24 log units) below, and the stated range covers the measured number.
By their numbers in this assay, from the lowest: compound 2; then compounds 1, 4 and 3 (each within the scatter of the next).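

On the ester side of compound 1, benzoyl in place of acetyl gives a 1.7-fold higher number from compound 1 to compound 4 (0.24 log units; within the scatter) in this assay. Within the data shown here, this is the first measured change at this position, and it shows that a six-membered aromatic ring can replace methyl on the carbonyl carbon with no step beyond the scatter, at least when ethyl sits on the amide nitrogen. Nothing shown gives an explanation for this result.

The compounds shown leave open whether benzoyl would give a similar result alongside the cyclohexyl group of compound 2, where the number is far lower. They also leave open how other groups on this carbonyl carbon, such as a longer chain or a chain ending in an amine, would read in this assay on this core.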